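The compounds below may be only part of what the source reports. "The series", "measured", "known", "first", "only" and "open" are said of these compounds alone.

Measured in an ADME assay on a cell-free system (plasma, Homo sapiens) for protein binding, with Plasma (Rattus norvegicus) as the target:
- compound 1 `Cc1ccn(-c2ccc(Cn3cc(C(=O)O)c(=O)c4c(F)cccc43)cc2)n1`: 92.3%
- compound 2 `O=C(O)c1cn(Cc2ccc(-n3ccc4cccnc43)cc2)c2cccc(F)c2c1=O`: 98.8%
- compound 3 `O=C(O)c1cn(Cc2ccc(-n3ccc4ncccc43)cc2)c2cccc(F)c2c1=O`: 96.1%

Compound 3 sits within the scatter of compound 1, as a 2.0-fold lower unbound fraction from compound 1 to compound 3 (0.30 log units; within the scatter) shows, so these two cannot be told apart. It does separate from the other measured compound, with a 3.3-fold higher unbound fraction from compound 2 to compound 3 (0.51 log units; beyond the scatter).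

Compound 4 `O=C(O)c1cn(Cc2ccc(N3CCOC3=O)cc2)c2cccc(F)c2c1=O` changes compound 3 in one place: a group of 6 heavy atoms (3 carbon, 1 nitrogen, 2 oxygen; one five-membered non-aromatic ring with 2 hetero atoms) in place of a group of 9 heavy atoms (7 carbon, 2 nitrogen; one five-membered aromatic ring with 1 hetero atom, one six-membered aromatic ring with 1 hetero atom), on an aromatic carbon. Within the data shown here, the entering group is 2-oxo-1,3-oxazolidin-3-yl, and no measured compound carries a non-aromatic ring there, so the data offer no direct precedent.

The nearest guide is compound 1, which also has a group of 6 heavy atoms at this place. Moving from it to larger groups gave a 6.4-fold lower unbound fraction from compound 1 to compound 2 (0.81 log units; beyond the scatter) and a 2.0-fold lower unbound fraction from compound 1 to compound 3 (0.30 log units; within the scatter), and only the first of these lies beyond the scatter. The two larger groups also differ from each other, so group size alone does not settle the outcome. A modest shift toward more free compound in this assay is therefore expected, though with little certainty.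

The estimated step is a 3.1-fold higher unbound fraction from compound 3 to compound 4 (0.49 log units; beyond the scatter).

For compound 4 the expected value is 88%, with an estimated range from 76% to 95%.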

Compound 4, plasma protein binding: 77.6%
Compound 4: middle estimate off by 1.9-fold (0.27 log units) (unbound fraction), on the low side; the measured number falls inside the stated range.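

In this assay, the 2-oxo-1,3-oxazolidin-3-yl group leaves more compound free than any of the three aromatic groups at this place, on the aromatic carbon para to a large group (a 5.7-fold higher unbound fraction from compound 3 to compound 4 (0.76 log units; beyond the scatter); a 2.9-fold higher unbound fraction from compound 1 to compound 4 (0.46 log units; beyond the scatter); a 19-fold higher unbound fraction from compound 2 to compound 4 (1.27 log units; beyond the scatter)). The step from compound 1 matters most, since the groups leaving and entering there have the same count of heavy atoms, so a change of group at equal size still moves the result beyond the scatter. The earlier compounds shown here held aromatic rings only at this place, and compound 4 now shows that a non-aromatic ring can be carried there and that the full spread at this place is larger than those compounds alone revealed.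

Nothing shown explains why the free fraction rises with this group. The compounds shown also cannot separate the loss of the aromatic ring from the presence of the ring oxygen or the carbonyl, and a comparison with a morpholine ring or a pyrrolidin-2-one ring at the same place would be needed to pull these apart.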